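Ester variation on a shared triterpenoid-like core: a nitrofuran ester

The compounds below may be only part of what the source reports. "The series", "measured", "known", "first", "only" and "open" are said of these compounds alone.

Measured so far in a functional assay on MDA-MB-231 cells (Homo sapiens) for antiproliferative activity, read by MTT assay, with a stated time of 72 h; a lower number here means a stronger inhibitor, a higher number a weaker inhibitor:
- Compound 1, `CC1=CC[C@H]2[C@H](CC[C@]2(C)O)C(C)(C)[C@@H]1CC[C@H]1[C@]2(C)CC[C@H](OC(=O)CCC(=O)O)C(C)(C)O[C@H]2CC[C@@]1(C)O`, gives 27900 nM.
- Compound 2, `CC1=CC[C@H]2[C@H](CC[C@]2(C)O)C(C)(C)[C@@H]1CC[C@H]1[C@]2(C)CC[C@H](OC(=O)c3ccc(C(F)(F)F)cc3)C(C)(C)O[C@H]2CC[C@@]1(C)O`, gives 19500 nM.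
- Compound 3, `COc1ccc(C(=O)O[C@H]2CC[C@]3(C)[C@H](CC[C@@](C)(O)[C@H]3CC[C@@H]3C(C)=CC[C@H]4[C@H](CC[C@]4(C)O)C3(C)C)OC2(C)C)cc1`, gives 30600 nM.

All three compounds share the same core and differ only in the acyl group of the ester. In this assay compound 3 shows the highest number of the three, but its separation from compound 1 is a 1.1-fold higher number from compound 1 to compound 3 (0.04 log units; within the scatter) and from compound 2 is a 1.6-fold higher number from compound 2 to compound 3 (0.20 log units; within the scatter), so no order among them can be stated. The step from compound 1 to compound 2, a 1.4-fold lower number from compound 1 to compound 2 (0.16 log units; within the scatter), likewise stays within the scatter. Every exchange of the acyl group seen so far has left the number essentially unchanged.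

Compound 4, `CC1=CC[C@H]2[C@H](CC[C@]2(C)O)C(C)(C)[C@@H]1CC[C@H]1[C@]2(C)CC[C@H](OC(=O)c3ccc([N+](=O)[O-])o3)C(C)(C)O[C@H]2CC[C@@]1(C)O`, carries a further variation at the same position:

5-nitrofuran-2-yl in place of 4-methoxyphenyl on a carbonyl carbon

Going by the values given here, the steps that bear on this change are those between compound 1, compound 2 and compound 3, which exchange aryl, substituted aryl and 2-carboxyethyl acyl groups without moving beyond the scatter. On that basis compound 4 is expected to give a number close to that of compound 3, with a step of a 1.2-fold lower number from compound 3 to compound 4 (0.09 log units; within the scatter) that is estimated to remain within the scatter. The estimate for compound 4 in this assay is 25000 nM, with an expected range from 10000 nM to 60000 nM.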

Compound 4, half-maximal inhibitory concentration: 11100 nM
Beside the measured number, compound 4's estimate is 2.3-fold (0.35 log units) above it, within the range that was stated.
By their numbers in this assay, from the lowest: compounds 4, 2, 1 and 3 (each within the scatter of the next, the first and the last beyond it).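

In this assay, going by these compounds alone, the 5-nitrofuran-2-yl group is the first acyl group at this position to give steps beyond the scatter, with a 2.8-fold lower number from compound 3 to compound 4 (0.44 log units; beyond the scatter) and a 2.5-fold lower number from compound 1 to compound 4 (0.40 log units; beyond the scatter), both modest, while every exchange among compound 1, compound 2 and compound 3 stayed within it. The position therefore does respond to the acyl group, though only modestly, and the response is incomplete: a 1.8-fold lower number from compound 2 to compound 4 (0.24 log units; within the scatter) stays within the scatter, so compound 4 cannot be set apart from compound 2 and the 4-(trifluoromethyl)phenyl ester remains level with it. No measurement is available that would account for this shift.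

The compounds shown leave open whether the step belongs to the nitro group or to the furan ring, since neither a plain furan-2-yl ester nor a 4-nitrophenyl ester stands among them to separate the two. They also leave open how the number would move with an amine on the acyl group, with a longer chain, or with the free hydroxyl in place of the ester.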